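Working notes: methoxy to methyl on the ester of compound 1

A few compounds are considered here, and "the series" means these few. Any claim that something is new, unique, unknown or untested is made for them only; others in the source may bear on it.

Measured so far:
compound 1, `CCOC(=O)C1=Cc2ccccc2OC1(OCc1cc(-c2ccc(OC)cc2)no1)C(F)(F)F`, gives in a functional assay on A549 cells (Homo sapiens) for inhibition, read by MTT assay, with a stated time of 24 h (on this read-out lower numbers stand for stronger inhibition and higher numbers for weaker inhibition), only a limit, > 150000 nM.
compound 2, `COc1ccc(-c2cc(COC3(C(F)(F)F)Oc4ccccc4C=C3C(=O)O)on2)cc1`, gives in this assay a number, 36200 nM.

Compound 1 stands at the limit of > 150000 nM in this assay, at which 1 of the 2 values shown sits, and has no number of its own; only compound 2 gives one. Among the measured compounds shown here, the single measured step, an at least 4.1-fold lower number from compound 1 to compound 2 (0.61 log units; beyond the scatter), comes from hydrogen in place of ethyl on an oxygen next to a carbonyl group, and nothing else has been varied.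

Compound 3, `CCOC(=O)C1=Cc2ccccc2OC1(OCc1cc(-c2ccc(C)cc2)no1)C(F)(F)F`, differs from compound 1 by methyl in place of methoxy on an aromatic carbon. For the measured compounds named here, no measured step touches this part of the shared core; the step from compound 1 to compound 2 changes the ester and so does not bear on it. Compound 3 keeps the ethyl ester of compound 1, and the limit of compound 1 is the only anchor for it. Compound 3 is therefore expected to sit close to that limit, with a number no higher from compound 1 to compound 3 (the limit leaves the size open) estimated as nothing beyond the scatter. Compound 3 may well again give only a limit rather than a number. Compound 3 is estimated at 150000 nM, between 50000 nM and 450000 nM.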

Compound 3, half-maximal inhibitory concentration: > 150000 nM
Compound 3: no number, only a limit (the forecaster's own chance of this, stated with the estimate: 65%); the middle value lies on the limit itself.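

In this assay compound 1 and compound 3 allow no readable step, as each gives only a limit: the limit of > 150000 nM in this assay, at which 2 of the 3 values shown sit.

The compounds shown leave open what 4-methoxyphenyl to 4-methylphenyl does to a compound that gives a number, such as one carrying hydrogen in place of ethyl as in compound 2.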